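A Urea Side Chain Change at the Assay Limit

The source may hold more compounds than are shown below. What is called first, only, known or untested is meant among the compounds shown, and "the series" means these compounds.

Values measured in a functional assay on SW-620 cells (Homo sapiens) (on this read-out higher numbers stand for weaker inhibition and lower numbers for stronger inhibition), are as follows.
Compound 1 `COc1cc(NC(C)CCCNC(=O)NCCO)c2ncccc2c1` gives > 100000 nM as a limit.
Compound 2 `COc1cc(NC(C)CCCNC(=O)NCCCCCO)c2ncccc2c1` gives 200 nM as a number.
Compound 3 `COc1cc(NC(C)CCCNC(=O)NC(CO)(CO)CO)c2ncccc2c1` gives > 100000 nM as a limit.

Compound 3 stands at the limit of > 100000 nM in this assay, at which 2 of the 3 values shown sit, and so has no number of its own. Compound 4 `COc1cc(NC(C)CCCNC(=O)N(CCO)CCO)c2ncccc2c1` differs from it by a single change bis(2-hydroxyethyl)amino in place of (2-hydroxy-1,1-bis(hydroxymethyl)ethyl)amino on a carbonyl carbon in which bis(2-hydroxyethyl)amino replaces (2-hydroxy-1,1-bis(hydroxymethyl)ethyl)amino on a carbonyl carbon. Two large steps bear on this, namely an at least 500-fold lower number from compound 1 to compound 2 (2.69 log units; beyond the scatter) and an at least 500-fold higher number from compound 2 to compound 3 (2.69 log units; beyond the scatter) and both lie beyond the scatter. Both turn on the 5-hydroxypentyl group, which compound 4 does not carry. The remaining step that the two limits leave unreadable from compound 1 to compound 3 has no readable size. The closest guide is compound 1 with its 2-hydroxyethyl group, which gives > 100000 nM as a limit. For the measured compounds named here, no large step is therefore expected, only a slight move towards a lower number if a number appears at all, and an at least 1.6-fold lower number from compound 3 to compound 4 (0.22 log units; that floor lies within the scatter) is the estimate. Compound 4 is estimated at 60000 nM with an expected range from 10000 nM to 100000 nM on this reasoning.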

Compound 4, half-maximal inhibitory concentration: > 100000 nM
Compound 4: only a limit was reported; the forecaster's own chance of this, stated with the estimate: 65%; at least 1.6-fold (0.22 log units) between middle value and limit.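

In this assay compound 4 gives > 100000 nM, which is a limit and not a number. Bis(2-hydroxyethyl)amino in place of (5-hydroxypentyl)amino on a carbonyl carbon brings an at least 500-fold higher number from compound 2 to compound 4 (2.69 log units; beyond the scatter), so carrying two 2-hydroxyethyl chains on this nitrogen does not restore the number that only the 5-hydroxypentyl group has given so far. The steps linking compound 4 to compound 1 and to compound 3 join two limits and cannot be read, so these three groups cannot be ranked against one another: the limit of > 100000 nM in this assay, at which 3 of the 4 values shown sit.

The compounds shown leave open whether the 5-hydroxypentyl chain needs its hydroxy group, since a plain pentyl chain, a 5-aminopentyl group and a chain ending in a carboxylic acid do not appear among them. They also leave open how a longer hydroxyalkyl chain would read out here.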